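Chloro on the benzyl ring: a second step to test

The source may report more compounds than this note shows. Statements on the series, on what has been measured and on what is new or still open speak of the compounds shown alone.

Three compounds have so far been measured in a functional assay on the whole organism (artery, strain albino) with Rattus norvegicus as the target, with a stated time of 300 min, at a dose of 10 mg/kg by the oral route; on this read-out higher numbers stand for more inhibition at the one dose given (going by the name of the read-out) and lower numbers for less inhibition:

compound 1, `CC1=C(C(=O)Nc2ccc(F)cc2)C(c2ccc([N+](=O)[O-])cc2)N=C(SCc2ccccc2)N1`, gives 38.5%
compound 2, `CC1=C(C(=O)Nc2ccc(F)cc2)C(c2ccc([N+](=O)[O-])cc2)N=C(SCc2cccc(Cl)c2)N1`, gives 18.5%
compound 3, `CC1=C(C(=O)Nc2ccc([N+](=O)[O-])cc2)C(c2cccc([N+](=O)[O-])c2)N=C(SCc2ccccc2)N1`, gives 25.6%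

Compounds 1 and 2 share one core and differ in a single place, (chloro in place of hydrogen on an aromatic carbon), the chlorine sitting meta to a large group. In this assay this change produced a number 20 percentage points lower from compound 1 to compound 2 (beyond the scatter). Compound 3 is built on a different core; how the two cores differ is not broken down here. The values of compound 3 and compound 2 lie within the scatter of each other, whereas compound 1 stands beyond the scatter above compound 3.

Compound 4, `CC1=C(C(=O)Nc2ccc([N+](=O)[O-])cc2)C(c2cccc([N+](=O)[O-])c2)N=C(SCc2ccccc2Cl)N1`, has not yet been measured. It differs from compound 3 by chloro in place of hydrogen on an aromatic carbon, with the chlorine ortho to a large group rather than meta to a large group as in compound 2, so it is the same kind of change, not the same one. Going by the values given here, the only measured example of this kind of change is the step from compound 1 to compound 2. Among the compounds with values here, a downward step of comparable size is expected, so that a number 13.6 percentage points lower from compound 3 to compound 4 (beyond the scatter) is the estimate, because a number 20 percentage points lower from compound 1 to compound 2 (beyond the scatter) was seen for the one measured example. Compound 4 is accordingly expected to give about 12% in this assay, with the estimate spanning 0% to 28%.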

Compound 4, a percentage reported as inhibition, in the whole organism at one dose (the size of the read-out at that dose, not a potency): 15.9%
Estimate against measurement, compound 4: 3.9 percentage points below, within the range that was stated.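

In this assay, putting chloro in place of hydrogen on the benzyl ring of the core of compound 3 gave a number 9.7 percentage points lower from compound 3 to compound 4 (within the scatter), and set beside the earlier example, the size of the step does not differ between the two cores: the same change on two cores in this assay, a number 20 percentage points lower (beyond the scatter) from compound 1 to compound 2 and a number 9.7 percentage points lower (within the scatter) from compound 3 to compound 4, 10.3 percentage points apart, within the scatter of two such steps On its own, the new step cannot be told from no change, whereas the earlier one lies beyond the scatter, so the two pairs are compatible with a change that carries from one core to the other but do not establish a loss on the core of compound 3. Nor do they show a rule for the series: there are only two pairs, read at a single oral dose, and the chlorine is not in the same place in both, being ortho to a large group in compound 4 only.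

The compounds shown leave open whether the place of the chlorine on the ring matters at all, as no single core carries the 2-chlorobenzyl group and the other chlorobenzyl group side by side. They also leave open what a methoxy group or an amine on the benzyl ring, or a longer chain in place of benzyl on the sulfur, would give in this assay.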